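Adding an Ethyl Group to the Ring Amine of Compound 1

The compounds below may be only part of what the source reports. "The series", "measured", "known", "first", "only" and "open" are said of these compounds alone.

Compound 1, `Clc1ccc2[nH]cc(SC3CCNCC3)c2c1`: 1.2 mg/kg
Compound 2, `Cc1[nH]c2ccc(Cl)cc2c1SC1CCNCC1`: 9.9 mg/kg
Compound 3, `Cc1[nH]c2ccc(Br)cc2c1SC1CCNCC1`: 3.1 mg/kg

All three compounds share one core and were tested in a functional assay on the whole organism with Mus musculus as the target, in the hot plate test; a lower number here means that less compound is needed, a higher number that more compound is needed for the effect. Compound 1 gives the lowest number of the three: compound 3 is the nearest to it and compound 2 the furthest, and both gaps lie beyond the scatter. Two single changes link the measured compounds. Putting a methyl group onto an aromatic carbon gave an 8.3-fold higher number from compound 1 to compound 2 (0.92 log units; beyond the scatter). Exchanging the chloro for a bromo on the aromatic ring gave a 3.2-fold lower number from compound 2 to compound 3 (0.50 log units; beyond the scatter).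

Compound 4, `CCN1CCC(Sc2c[nH]c3ccc(Cl)cc23)CC1`, has not yet been measured in this assay. It differs from compound 1 by ethyl in place of hydrogen on an amine nitrogen in a ring. For the measured compounds named here, neither of the measured steps touches this amine nitrogen; both sit on the aromatic part of the core, so no step bears on this change directly. Going by the values given here, the only measured step that adds carbon, from compound 1 to compound 2, raised the number. On that weak footing a modest rise in the number is expected for compound 4, with wide uncertainty, as a 2.5-fold higher number from compound 1 to compound 4 (0.40 log units; beyond the scatter). Compound 4 is therefore estimated at 3 mg/kg, within a range from 1 mg/kg to 12 mg/kg.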

Compound 4, dose for half-maximal effect: 33.3 mg/kg
For compound 4 the middle estimate is 11-fold (1.05 log units) below the measured one, outside the stated range (above it).
By their numbers in this assay, from the lowest: compound 1; then compound 3; then compound 2; then compound 4.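

In this assay, the ring amine nitrogen proves to be a sensitive place: ethyl in place of hydrogen there gives a 28-fold higher number from compound 1 to compound 4 (1.44 log units; beyond the scatter), a large step and the first measured change away from the aromatic part of the core. That step is larger than the one for methyl in place of hydrogen on an aromatic carbon, an 8.3-fold higher number from compound 1 to compound 2 (0.92 log units; beyond the scatter), so in this pair of changes the small carbon group on the amine nitrogen moves the number further than the one on the aromatic carbon. Nothing available here explains why the number rises so far with ethyl on this nitrogen.

The compounds shown carry only hydrogen and ethyl on this nitrogen, so it remains open whether a methyl group, a longer chain such as propyl, or a benzyl group would raise the number less, equally or more. Going by these compounds, it is also open whether ethyl would raise the number to a similar extent in compound 2 and compound 3, where the amine nitrogen still carries hydrogen.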